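Aryl group replacing a non-ring substituent on the shared core

The source may hold more compounds than are shown below. What is called first, only, known or untested is meant among the compounds shown, and "the series" means these compounds.

Compound 1 `Cc1cc(NC(C)C)nc(SCc2nc3ccccc3[nH]2)n1`, compound 2 `Cc1cc(NCCO)nc(SCc2nc3ccccc3[nH]2)n1` and compound 3 `Cc1cc(NNC(N)=S)nc(SCc2nc3ccccc3[nH]2)n1` share one core and differ only in the group on a nitrogen on an aromatic ring. In a functional assay on ECa-109 cells (Homo sapiens) for cytotoxicity, read by MTT assay, with a stated time of 72 h (on this read-out lower numbers stand for stronger inhibition and higher numbers for weaker inhibition), compound 1 reaches only the limit > 100000 nM. In this assay compound 2 likewise reaches only the limit > 100000 nM. Compound 3 also stands at the limit > 100000 nM in this assay, so its position is known only as a limit, not as a number. Since all values shown sit at this limit (the limit of > 100000 nM in this assay, at which 3 of the 3 values shown sit), the steps a step that the two limits leave unreadable from compound 1 to compound 2, a step that the two limits leave unreadable from compound 1 to compound 3 and a step that the two limits leave unreadable from compound 2 to compound 3 carry no readable size. Compound 4 `Cc1ccc(Nc2cc(C)nc(SCc3nc4ccccc4[nH]3)n2)cc1` changes compound 3 by a group of 7 heavy atoms (7 carbon; one six-membered aromatic ring of carbon only) in place of a group of 4 heavy atoms (1 carbon, 2 nitrogen, 1 sulfur; no ring), on a nitrogen on an aromatic ring. For the measured compounds named here, none of the measured steps has a readable size that bears on this change, and no measured compound carries a ring at this nitrogen, so the expectation rests on the unbroken limit alone. The step expected in this assay is an at least 1.2-fold lower number from compound 3 to compound 4 (0.09 log units; that floor lies within the scatter), with no direction claimed beyond the scatter. Compound 4 is estimated at 80000 nM, in the range 10000 nM to 300000 nM, with a fair chance that this assay again reports only a limit.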

Compound 4, half-maximal inhibitory concentration: 57300 nM
For compound 4 the middle estimate is 1.4-fold (0.14 log units) above the measured one; low and high end bracket the measured number.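

With 4-methylphenyl on the nitrogen on an aromatic ring, compound 4 is the only compound shown that gives a number rather than a limit in this assay, so this position can hold a group with a readable result. Against the three limits, the change gives an at least 1.7-fold lower number from compound 3 to compound 4 (0.24 log units; that floor lies within the scatter), an at least 1.7-fold lower number from compound 2 to compound 4 (0.24 log units; that floor lies within the scatter) and an at least 1.7-fold lower number from compound 1 to compound 4 (0.24 log units; that floor lies within the scatter); these are floors rather than sizes, so they establish no gain beyond the scatter. The steps among compounds 1, 2 and 3 still cannot be read, and the series remains mostly at one limit: the limit of > 100000 nM in this assay, at which 3 of the 4 values shown sit.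

As far as these compounds go, what an unsubstituted phenyl or a benzyl group would give at this nitrogen stays open, so the contributions of the ring and its methyl cannot be separated. From the compounds shown here alone, how far each true step lies beyond its floor also stays open.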